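The source may report more compounds than this note shows. Statements on the series, on what has been measured and on what is new or still open speak of the compounds shown alone.

Compound 1 `Cc1oc(-c2c(C)c(C)c(C)c(C)c2C)nc1CN1CCC(C(=O)NCCCN2C[C@H](C)C[C@H](C)C2)CC1` was tested in an ADME assay on Huh7.5.1 cells (Homo sapiens) for cytotoxicity, read by ATP content, with a stated time of 48 h (on this read-out lower numbers stand for higher toxicity in this test and higher numbers for lower toxicity in this test), where compound 1 gives 8180 nM. For the measured compounds named here, of the two numbers measured so far this is the lowest; the other belongs to compound 2 `Cc1ccccc1-c1nc(CN2CCC(C(=O)N3CCN(CCN(C)C)CC3)CC2)c(C)o1`, which in this assay gives 27200 nM, a gap beyond the usual scatter. Compound 3 `COc1cccc(Cl)c1-c1nc(CN2CCC(C(=O)NCCCN3C[C@H](C)C[C@H](C)C3)CC2)c(C)o1` is not yet measured. Going by the values given here, it differs from compound 1 in one place: 2-chloro-6-methoxyphenyl in place of 2,3,4,5,6-pentamethylphenyl on an aromatic carbon No measured pair shows what this change does, so only a small step is expected, leaning toward a higher number. The expected step is a 1.5-fold higher number from compound 1 to compound 3 (0.17 log units; within the scatter). Compound 3 is estimated at 12000 nM, with a range from 5000 nM to 30000 nM.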

Compound 3, half-maximal cytotoxic concentration: 15800 nM
Estimate against measurement, compound 3: 1.3-fold (0.12 log units) below; measured number inside the range.
By their numbers in this assay, from the lowest: compounds 1, 3 and 2 (each within the scatter of the next, the first and the last beyond it).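

On the aromatic carbon of the five-membered ring, 2-chloro-6-methoxyphenyl in place of 2,3,4,5,6-pentamethylphenyl gives a 1.9-fold higher number from compound 1 to compound 3 (0.29 log units; within the scatter) in this assay and so leaves the two compounds indistinguishable in this test. An all-carbon group can thus give way to one carrying chlorine, oxygen and a hydrogen-bond acceptor without a change that can be told from the scatter. No measurement shown gives a reason for this outcome.

Still open, from the compounds shown here alone, is whether a different group at this position, such as an amine or a carboxylic acid, would stand apart from compound 1 in this assay beyond the scatter.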